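A few compounds are considered here, and "the series" means these few. Any claim that something is new, unique, unknown or untested is made for them only; others in the source may bear on it.

Measured compounds in a functional assay with Alpha-1A adrenergic receptor (Homo sapiens) as the target, read by calcium flux; on this read-out lower numbers stand for smaller maximal responses and higher numbers for larger maximal responses:
compound 1 `c1c[nH]c(-c2ccccc2OCC2=NCCN2)c1` gives 99%;
compound 2 `c1ccc(-c2cc[nH]n2)c(OCC2=NCCN2)c1` gives 119%;
compound 3 `Cc1cc(-c2ccccc2OCC2=NCCN2)sn1` gives 75%.

Compound 3 stands lowest of the three in this assay, with compound 1 nearest and compound 2 furthest above it. Compound 4 `Cn1nccc1-c1ccccc1OCC1=NCCN1` differs from compound 3 in one place: 1-methyl-1H-pyrazol-5-yl in place of 3-methyl-1,2-thiazol-5-yl on an aromatic carbon. The two steps that bear on this are a number 24 percentage points lower from compound 1 to compound 3 (beyond the scatter) and a number 44 percentage points lower from compound 2 to compound 3 (beyond the scatter), both beyond the scatter, both downward when the 3-methyl-1,2-thiazol-5-yl group enters. Reversing that kind of exchange is therefore expected to raise the maximum in this assay, though compound 4 carries no hydrogen-bond donor on the entering ring, unlike compound 1 and compound 2. Compound 4 is estimated at 95% in this assay, in the range 70% to 125%, a step of a number 20 percentage points higher from compound 3 to compound 4 (beyond the scatter).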

Compound 4, largest response reached (reported as maximum), in percent of the reference or control that the assay uses: 107%
The estimate for compound 4 lay 12 percentage points below the measured number; the measured number falls inside the stated range.
By their numbers in this assay, from the lowest: compound 3; then compounds 1 and 4 (each within the scatter of the next); then compound 2.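

In this assay, the exchange gives a number 32 percentage points higher from compound 3 to compound 4 (beyond the scatter), and since 1-methyl-1H-pyrazol-5-yl and 3-methyl-1,2-thiazol-5-yl both carry no hydrogen-bond donor, a donor on the ring at this position is not needed for a high maximum. Set against the rings that do carry one, the result is split: a number 8 percentage points higher from compound 1 to compound 4 (within the scatter), yet a number 12 percentage points lower from compound 2 to compound 4 (beyond the scatter). Nothing measured here explains these steps. The compounds shown leave open how an amine or a carboxylic acid on this ring, or a chain longer than methyl on its nitrogen, would change the maximum.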